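The source may hold more compounds than are shown below. What is called first, only, known or untested is meant among the compounds shown, and "the series" means these compounds.

Compound 2 `Fc1ccc(-c2cc3c(cn2)ncn3-c2ccc(OC(F)F)cc2)c(C(F)(F)F)c1` gives 1500 nM in a functional assay on HL-60 cells (Homo sapiens) for activation, read by flow cytometry, with a stated time of 4 days (a higher number here means that more compound is needed for the effect, a lower number that less compound is needed), and stands lowest of the two numbers measured. Compound 1 `Fc1ccc(-c2cc3c(cn2)ncn3-c2ccc(OC(F)F)cc2)cc1` gives 10000 nM in this assay. For the measured compounds named here, the single known step is a 6.7-fold lower number from compound 1 to compound 2 (0.82 log units; beyond the scatter). Compound 3 `CC(C)Oc1cc(F)ccc1-c1cc2c(cn1)ncn2-c1ccc(OC(F)F)cc1` differs from compound 2 by isopropoxy in place of trifluoromethyl on an aromatic carbon. Going by the values given here, that measured step only shows that placing a group on that aromatic carbon lowered the number; no measured step compares isopropoxy with trifluoromethyl, so the direction stays open. For compound 3 the expected step is a 1.3-fold higher number from compound 2 to compound 3 (0.12 log units; within the scatter). Compound 3 is therefore estimated at 2000 nM with a range from 500 nM to 8000 nM.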

Compound 3, half-maximal effective concentration: 1100 nM
Compound 3: the middle estimate sits 1.8-fold (0.26 log units) above what was measured; the measured number falls inside the stated range.
By their numbers in this assay, from the lowest: compounds 3 and 2 (each within the scatter of the next); then compound 1.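

Trifluoromethyl and isopropoxy share a count of four heavy atoms but differ in their atoms, and swapping one for the other on this aromatic carbon gives a 1.4-fold lower number from compound 2 to compound 3 (0.13 log units; within the scatter), so the two cannot be told apart here. Set against hydrogen, isopropoxy gives a 9.1-fold lower number from compound 1 to compound 3 (0.96 log units; beyond the scatter), which shows that the drop in the number is not limited to trifluoromethyl. No measured evidence accounts for this result. Going by these compounds, it remains open whether a smaller group such as methoxy would do the same on this carbon, and how an amine or a carboxylic acid would behave there.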